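The compounds below may be only part of what the source reports. "The series", "measured", "known", "first", "only" and "open" are said of these compounds alone.

In an ADME assay on microsomes from liver (Rattus norvegicus) for metabolic stability (a lower number here means that the compound disappears faster, a higher number that the compound lasts longer), compound 3 `Nc1nc(NCCNc2ncc(-c3ncc[nH]3)c(-c3cc(F)c(Cl)cc3Cl)n2)ccc1[N+](=O)[O-]` gives > 0.5 h, which is a limit and not a number. Compound 1 `Nc1nc(NCCNc2ncc(-c3ncc[nH]3)c(-c3ccccc3Br)n2)ccc1[N+](=O)[O-]` gives > 0.5 h, also a limit. Compound 2 `Nc1nc(NCCNc2ncc(-c3ncc[nH]3)c(-c3cc(F)ccc3Cl)n2)ccc1[N+](=O)[O-]` gives > 0.5 h, again a limit. Compound 3 therefore shares (the limit of > 0.5 h in this assay, at which 3 of the 3 values shown sit), and no order among these compounds can be read.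

The change considered here leads to compound 4 `Nc1nc(NCCNc2ncc(-c3ncc[nH]3)c(-c3ccc(Cl)cc3Br)n2)ccc1[N+](=O)[O-]`: 2-bromo-4-chlorophenyl in place of 2,4-dichloro-5-fluorophenyl on an aromatic carbon. In words, 2-bromo-4-chlorophenyl takes the place of 2,4-dichloro-5-fluorophenyl on an aromatic carbon. Going by the values given here, three measured steps bear on this swap, since each alters the group at that same place: a step that the two limits leave unreadable from compound 1 to compound 3, a step that the two limits leave unreadable from compound 2 to compound 3 and a step that the two limits leave unreadable from compound 1 to compound 2. None of them offers a size to carry over. With no readable step to scale from, no step beyond the usual scatter is expected in this assay, and no direction is expected either. The step estimated here is a step that the limit leaves unreadable from compound 3 to compound 4. For compound 4 the half-life is estimated at 0.8 h, within an expected range from 0.4 h to 2 h.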

Compound 4, half-life: > 0.5 h
Compound 4 gave a limit, no number; the forecaster's own chance of this, stated with the estimate: 85%; the middle value does not contradict the limit.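

The steps from compound 1, compound 2 and compound 3 to compound 4 cannot be read, as all four compounds give a limit rather than a number: the limit of > 0.5 h in this assay, at which 4 of the 4 values shown sit. Going by these compounds, the actual half-lives in this assay remain open, and so does whether these group swaps change them at all.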